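The source may report more compounds than this note shows. Statements on the series, on what has been measured and on what is new or still open speak of the compounds shown alone.

Measured compounds:
compound 1, `CCN(C)C(=N)NC(=N)Nc1ccc(C(F)(F)F)cc1`, 5700 nM
compound 2, `CCCCCCCNC(=N)NC(=N)Nc1ccc(F)c(F)c1`, 4300 nM

Two biguanides have been measured in a functional assay on T-24 cells (Homo sapiens) for antiproliferative activity, read by MTT assay, with a stated time of 72 h; a lower number here means a stronger inhibitor, a higher number a weaker inhibitor. Compound 1 gives 5700 nM in this assay, the highest of the two numbers, and compound 2 gives 4300 nM. The two values lie within the scatter of each other, so the numbers on their own separate neither compound from the other.

The step considered here leads from compound 1 to compound 3, `CCN(CC)C(=N)NC(=N)Nc1ccc(C(F)(F)F)cc1`, which has not yet been tested in this assay. The two structures differ by methyl in place of hydrogen on a saturated chain carbon bound to an amine nitrogen. Within the data shown here, no measured pair in this set shows what such a change does to the number in this assay, so there is no step to lean on.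

Among the measured compounds shown here, with the change confined to an alkyl group on the amine, and with no measured pair to suggest a direction, the expected step of a 1.1-fold lower number from compound 1 to compound 3 (0.06 log units; within the scatter) is none beyond the scatter. Compound 3 is therefore estimated at 5000 nM in this assay, with a range from 2500 nM to 10000 nM.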

Compound 3, half-maximal inhibitory concentration: 6200 nM
Compound 3: the middle estimate sits 1.2-fold (0.09 log units) below what was measured, and the stated range covers the measured number.
By their numbers in this assay, from the lowest: compounds 2, 1 and 3 (each within the scatter of the next).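

In this assay, the change from methyl to ethyl, which turns the ethyl(methyl)amino group into diethylamino, comes with a 1.1-fold higher number from compound 1 to compound 3 (0.04 log units; within the scatter). Among these compounds, this is the first measured pair at this place, a saturated chain carbon bound to an amine nitrogen, and it shows that this single added methyl leaves the number inside the scatter, so the two compounds cannot be told apart here on this reading. No measured property or other finding is at hand that bears on this result.

The compounds shown leave open whether a longer chain on the amine, such as butyl or hexyl, or a hydroxyl group at the end of one ethyl chain, would carry the number beyond the scatter in this assay. They also leave open whether the same methyl-to-ethyl change would stay this small if a chlorine atom or a nitrile stood in place of the trifluoromethyl group on the core of compound 1.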